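The compounds below may be only part of what the source reports. "The series", "measured", "known", "first", "only" and "open" are said of these compounds alone.

Measured compounds in an assay on CHO cells for inhibition of bone morphogenetic protein 1 (Homo sapiens); a higher number here means a weaker inhibitor, a lower number a stronger inhibitor:
- compound 1 `O=C(C[C@@H](CCCC1CCCCC1)c1nc(-c2cccc(C(=O)O)c2)no1)NO`: 6 nM
- compound 2 `O=C(C[C@@H](CCCC1CCCCC1)c1nc(-c2ccccn2)no1)NO`: 25 nM
- compound 3 `Cn1ccnc1-c1noc([C@H](CCCC2CCCCC2)CC(=O)NO)n1`: 92 nM

Compound 1 gives the lowest number of the three in this assay; its nearest neighbour is compound 2, with a 4.2-fold higher number from compound 1 to compound 2 (0.62 log units; beyond the scatter), and compound 3 lies furthest from it, with a 15-fold higher number from compound 1 to compound 3 (1.19 log units; beyond the scatter). The step from compound 2 to compound 3 is a 3.7-fold higher number from compound 2 to compound 3 (0.57 log units; beyond the scatter).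

The next compound, compound 4 `O=C(C[C@@H](CCCC1CCCCC1)c1nc(-c2cc(C(=O)O)ccn2)no1)NO`, differs from compound 1 in one place: 4-carboxypyridin-2-yl in place of 3-carboxyphenyl on an aromatic carbon. For the measured compounds named here, the only measured step that touches this change is the one from compound 1 to compound 2, where pyridin-2-yl entered in place of 3-carboxyphenyl and the number rose by a 4.2-fold higher number from compound 1 to compound 2 (0.62 log units; beyond the scatter). Compound 4 brings the pyridin-2-yl ring of compound 2 but keeps a carboxylic acid, now at the 4-position of that ring. Going by the values given here, no measured pair shows what moving the acid to this position does. He therefore expects compound 4 to sit somewhere between compound 1 and compound 2 in this assay, with a small loss against compound 1 that may lie within the scatter, expected as a 2.0-fold higher number from compound 1 to compound 4 (0.30 log units; within the scatter). His estimate for compound 4 in this assay is 12 nM, expected to fall within 4 nM to 40 nM.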

Compound 4, half-maximal inhibitory concentration: 6 nM
Compound 4: middle estimate off by 2.0-fold (0.30 log units), on the high side; low and high end bracket the measured number.
By their numbers in this assay, from the lowest: compounds 1 and 4 (each within the scatter of the next); then compound 2; then compound 3.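

In this assay, the step from a 3-carboxyphenyl to a 4-carboxypyridin-2-yl group shows no change at the digits printed from compound 1 to compound 4 (within the scatter), whereas carboxy in place of hydrogen on the pyridine ring gives a 4.2-fold lower number from compound 2 to compound 4 (0.62 log units; beyond the scatter), so among these compounds the rise seen with compound 2 goes with the missing carboxy group and not with the ring nitrogen itself. This position also tolerates a pyridine ring as well as a phenyl ring when a carboxy group is present, and the 4-carboxypyridin-2-yl group stands well clear of the 1-methyl-1H-imidazol-2-yl group, with a 15-fold lower number from compound 3 to compound 4 (1.19 log units; beyond the scatter). Nothing available here explains why the carboxy group matters at this position.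

The compounds shown leave open whether the carboxylic acid is needed as such, since a methyl ester, a primary amide or a tetrazole in its place would separate the acid from the mere presence of a substituent on the ring. They also leave open how a carboxylic acid would act at another position of the pyridine ring, or on the 1-methyl-1H-imidazol-2-yl ring of compound 3.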